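Chlorobenzyl isomers on a dihydropyrimidine amide scaffold

This account rests on a few compounds, and the source may have more. Where it says the series, first, only, none or still open, it means among the compounds named here.

Measured so far:
Compound 1, `COc1ccc(C2N=C(SCc3cccc(Cl)c3)NC(C)=C2C(=O)Nc2ccc(F)cc2)cc1OC`, 15.5%
Compound 2, `COc1ccc(C2N=C(SCc3ccc(Cl)cc3)NC(C)=C2C(=O)Nc2ccc(F)cc2)cc1OC`, 22.2%
Compound 3, `CC1=C(C(=O)Nc2ccc(Br)cc2)C(c2ccc(Cl)cc2Cl)N=C(SCc2cccc(Cl)c2)N1`, 11.3%

Three compounds were examined in a functional assay on the whole organism (artery, strain albino) with Rattus norvegicus as the target, with a stated time of 720 min, at a dose of 10 mg/kg by the oral route; a higher number here means more inhibition at the dose given (going by the name of the read-out), a lower number less inhibition. Compound 1 `COc1ccc(C2N=C(SCc3cccc(Cl)c3)NC(C)=C2C(=O)Nc2ccc(F)cc2)cc1OC` gives 15.5%, and compound 2 `COc1ccc(C2N=C(SCc3ccc(Cl)cc3)NC(C)=C2C(=O)Nc2ccc(F)cc2)cc1OC` gives 22.2%. The two share a core and differ in one place only, (4-chlorophenyl in place of 3-chlorophenyl on a saturated chain carbon bound to a sulfur); this step gives a number 6.7 percentage points higher from compound 1 to compound 2 (within the scatter). Compound 3 `CC1=C(C(=O)Nc2ccc(Br)cc2)C(c2ccc(Cl)cc2Cl)N=C(SCc2cccc(Cl)c2)N1` gives 11.3% in this assay. Its value is the lowest of the three, but only compound 2 lies beyond the scatter from it, while compound 1 lies within it. The difference between the core of compound 1 and the core of compound 3 is not broken down here.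

Compound 4 `CC1=C(C(=O)Nc2ccc(Br)cc2)C(c2ccc(Cl)cc2Cl)N=C(SCc2ccc(Cl)cc2)N1` has not yet been measured in this assay. It is related to compound 3 by the same kind of change that links compound 1 and compound 2, namely (4-chlorophenyl in place of 3-chlorophenyl on a saturated chain carbon bound to a sulfur). Both changes sit at the same place, on a saturated chain carbon bound to a sulfur, on their own cores. Within the data shown here, the only step on record for this change is the one from compound 1 to compound 2, which stayed within the scatter. Resting on that single observation, a step of similar size is expected from compound 3 to compound 4, a number 6.7 percentage points higher from compound 3 to compound 4 (within the scatter), though a single step within the scatter is a narrow basis for this. Compound 4 is therefore estimated at 18% in this assay, with a range from 8% to 30%.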

Compound 4, a percentage reported as inhibition, in the whole organism at one dose (the size of the read-out at that dose, not a potency): 25.8%
Compound 4: middle estimate off by 7.8 percentage points, on the low side; low and high end bracket the measured number.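

In this assay, putting 4-chlorophenyl in place of 3-chlorophenyl on a saturated chain carbon bound to a sulfur gives a number 14.5 percentage points higher from compound 3 to compound 4 (beyond the scatter). Set beside the earlier step, the same change points the same way on both cores, and the two steps cannot be told apart in size: the same change on two cores in this assay, a number 6.7 percentage points higher (within the scatter) from compound 1 to compound 2 and a number 14.5 percentage points higher (beyond the scatter) from compound 3 to compound 4, 7.8 percentage points apart, within the scatter of two such steps. This agrees with the change carrying over from the core of compound 1 to the core of compound 3, but it rests on two pairs only, just one of the two steps lies beyond the scatter, and it shows neither that the size of the step is fixed nor that the change would behave the same way on any further core.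

The compounds shown leave open what other groups would do at this place, as only 3-chlorobenzyl and 4-chlorobenzyl appear there, so a plain benzyl, a longer chain or a carboxylic acid on the sulfur remains unaddressed. They also leave open which of the several differences between the two cores matters, and whether the step seen at this single dose would hold at other doses.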